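Thiophene for phenyl on two nucleoside cores, cell viability

A few compounds are considered here, and "the series" means these few. Any claim that something is new, unique, unknown or untested is made for them only; others in the source may bear on it.

Measured compounds:
compound 1 `CNc1ncnc2c1c(-c1ccccc1)cn2[C@@H]1O[C@H](CO)[C@@H](O)[C@H]1O` gives > 100000 nM in an ADME assay on BJ cells (Homo sapiens), read by MTT assay, with a stated time of 72 h; on this read-out lower numbers stand for stronger inhibition and higher numbers for weaker inhibition
compound 2 `CNc1ncnc2c1c(-c1ccsc1)cn2[C@@H]1O[C@H](CO)[C@@H](O)[C@H]1O` gives > 100000 nM in this assay
compound 3 `Nc1nc2c(c(-c3ccccc3)cn2[C@@H]2O[C@H](CO)[C@@H](O)[C@H]2O)c(=O)[nH]1` gives > 100000 nM in this assay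

Each of these three values is a limit of this assay, not a measured number. For compound 1 the value is a limit. For compound 2 the value is also a limit. For compound 3 the value is again a limit. The change from compound 1 to compound 2 is thiophen-3-yl in place of phenyl on an aromatic carbon, and its step is a step that the two limits leave unreadable from compound 1 to compound 2, since both sit at the limit of > 100000 nM in this assay, at which 3 of the 3 values shown sit. How the core of compound 3 differs from that of compound 1 is not broken down here. Compound 4 `Nc1nc2c(c(-c3ccsc3)cn2[C@@H]2O[C@H](CO)[C@@H](O)[C@H]2O)c(=O)[nH]1`, not yet measured, carries the same change on the core of compound 3, namely (thiophen-3-yl in place of phenyl on an aromatic carbon). Given that compound 3 sits at the limit of > 100000 nM in this assay, at which 3 of the 3 values shown sit, compound 4 is expected to remain at the limit, with an estimated step that the limit leaves unreadable from compound 3 to compound 4. The estimate for compound 4 in this assay is 150000 nM.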

Compound 4, half-maximal inhibitory concentration: > 100000 nM
Compound 4 was reported as a limit (the forecaster's own chance of this, stated with the estimate: 85%); the middle value is on the limit's open side.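

No step can be read from compound 3 to compound 4, because both values are limits: the limit of > 100000 nM in this assay, at which 4 of the 4 values shown sit. The compounds shown leave open whether thiophen-3-yl in place of phenyl changes inhibition on either core.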